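Nitro in place of isopropyl on a sparingly soluble compound

The source may hold more compounds than are shown below. What is called first, only, known or untested is meant among the compounds shown, and "the series" means these compounds.

For the measured compounds named here, only two compounds have so far been measured in a physicochemical assay for solubility; a lower number here means a less soluble compound, a higher number a more soluble compound. Compound 1 (`O=C(Nc1ccc([N+](=O)[O-])cc1Cl)c1cccc2cc[nH]c12`) gives < 1 ug/mL, which is a limit of the assay and not a number. Going by the values given here, compound 2 (`CC(C)c1cnc(NC(=O)c2cc(Cl)ccc2O)s1`) gives 1 ug/mL, the only actual number available. Among the compounds with values here, no measured pair yet shows what a single change does.

Compound 3 (`O=C(Nc1ncc([N+](=O)[O-])s1)c1cc(Cl)ccc1O`) carries nitro in place of isopropyl on an aromatic carbon, next to the ring sulfur (nitro in place of isopropyl on an aromatic carbon). Within the data shown here, with no measured step to size this change, the expectation in this assay rests on compound 2 at 1 ug/mL as the sole anchor. The estimated step of a 1.5-fold higher number from compound 2 to compound 3 (0.18 log units; within the scatter) is a small rise that stays inside the usual scatter. For compound 3 the estimated value is 1.5 ug/mL, with an expected range from 0.6 ug/mL to 5 ug/mL.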

Compound 3, solubility: > 44 ug/mL
Compound 3: no number, only a limit (the forecaster's own chance of this, stated with the estimate: 35%); middle value at least 29-fold (1.46 log units) away from the limit.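

In this assay, for the compounds shown here, nitro in place of isopropyl on this aromatic carbon, next to the ring sulfur, gives an at least 44-fold higher number from compound 2 to compound 3 (1.64 log units; beyond the scatter), the first measured step and one that lies beyond the scatter. The reading for compound 3 is a limit and not a number: the limit of > 44 ug/mL in this assay, at which 1 of the 3 values shown sits. So this position is not a silent one: with the rest of the molecule unchanged, this single exchange separates a compound with a read-out close to the bottom of the values shown from one at the upper limit.

The compounds shown leave open whether this rise is particular to nitro or would also follow from another group on the same carbon, such as a nitrile, an amine or a carboxylic acid. They also leave open how far beyond its limit compound 3 lies, and whether the same exchange would do as much on a different core.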